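The compounds below may be only part of what the source reports. "The series", "measured", "known", "first", "only" and "open" are said of these compounds alone.

Measured so far in an ADME assay on Vero cells (Chlorocebus sabaeus) for cytotoxicity, read by resazurin assay, with a stated time of 72 h (on this read-out lower numbers stand for stronger inhibition and higher numbers for weaker inhibition), are three compounds:
- compound 1 (`O=C(CCN1CCN(c2ccc([N+](=O)[O-])cc2)CC1)c1ccc(F)cc1`) gives 111000 nM
- compound 2 (`O=C(CCN1CCN(c2ccc([N+](=O)[O-])cc2)CC1)c1ccc(F)c(Br)c1`) gives 256000 nM
- compound 3 (`O=C(CCN1CCN(c2ccc([N+](=O)[O-])cc2)CC1)c1ccc(F)c(F)c1`) gives 122000 nM

Compound 1 sits at the low end of these numbers. Its nearest neighbour lies within the scatter (a 1.1-fold higher number from compound 1 to compound 3 (0.04 log units; within the scatter)) and its furthest lies modestly beyond it (a 2.3-fold higher number from compound 1 to compound 2 (0.36 log units; beyond the scatter)). Compound 4 (`O=C(CCN1CCN(c2ccc([N+](=O)[O-])cc2)CC1)c1ccc(C(F)(F)F)cc1`) has not yet been measured. It carries trifluoromethyl in place of fluoro on an aromatic carbon, para to a large group. Among the measured compounds shown here, no measured step makes this exact change, so the nearest guides are other exchanges on an aromatic carbon. Fluoro in place of hydrogen stayed within the scatter (a 1.1-fold higher number from compound 1 to compound 3 (0.04 log units; within the scatter)), bromo in place of hydrogen gave a modest rise (a 2.3-fold higher number from compound 1 to compound 2 (0.36 log units; beyond the scatter)), and fluoro in place of bromo gave a modest drop (a 2.1-fold lower number from compound 2 to compound 3 (0.32 log units; beyond the scatter)). With steps this small, only a slight upward move is expected in this assay, close to the scatter. The estimated step is a 1.3-fold higher number from compound 1 to compound 4 (0.10 log units; within the scatter) (small, and uncertain in direction). Compound 4 is estimated at 140000 nM (expected range 65000 nM to 280000 nM).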

Compound 4, half-maximal inhibitory concentration: 75700 nM
Estimate against measurement, compound 4: 1.8-fold (0.27 log units) above, within the range that was stated.
By their numbers in this assay, from the lowest: compounds 4, 1 and 3 (each within the scatter of the next); then compound 2.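

In this assay, among the compounds shown here, all the earlier compounds kept fluoro on this aromatic carbon, para to a large group, so this is the first exchange of that group itself, and it gives a 1.5-fold lower number from compound 1 to compound 4 (0.17 log units; within the scatter). Going from the one heavy atom of fluoro to the four heavy atoms of trifluoromethyl at this place therefore leaves the number within the scatter, and the result gives no direction for the change. Nothing available explains this outcome.

The compounds shown leave open whether an amine, a carboxylic acid or a hydroxyl group at this place would also stay within the scatter, or whether any of them would move the number beyond it. They also leave open what a longer chain between the carbonyl and the rest of the shared core would do.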